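The source may report more compounds than this note shows. Statements on the series, on what has been measured and on what is new or still open speak of the compounds shown alone.

Three compounds sharing one core have been looked at so far in a functional assay on MCF7 cells (Homo sapiens) for cytotoxicity, read by MTT assay, with a stated time of 72 h; a higher number here means a weaker inhibitor, a lower number a stronger inhibitor. Compound 1 `CS(=O)(=O)Oc1c(C(=O)NCc2ccc(F)cc2)nc(Br)c2cccnc12` has no usable result, its entry reading "not determined" (no result reported). Compound 2 `NCCCNc1c(C(=O)NCc2ccc(F)cc2)nc(Br)c2cccnc12` gives 6000 nM, and compound 3 `NCCNc1c(C(=O)NCc2ccc(F)cc2)nc(Br)c2cccnc12` gives 6000 nM, so compound 3 stands level with compound 2 and the two cannot be told apart.

The next compound to test is compound 4 `COC(=O)CNc1c(C(=O)NCc2ccc(F)cc2)nc(Br)c2cccnc12`. Going there from compound 3 places methoxycarbonyl in place of aminomethyl on a saturated chain carbon bound to a nitrogen on an aromatic ring. Put another way, (2-aminoethyl)amino gives way to ((methoxycarbonyl)methyl)amino.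

Among the compounds with values here, only one measured step bears on this change: no change at the digits printed from compound 2 to compound 3 (within the scatter). That step lies within the scatter, but an amino group stays on the chain in both of its compounds, whereas here the aminomethyl leaves altogether. Within the data shown here, it is therefore a weak guide, and no measured pair shows what losing that group does. A small move towards a weaker number is expected, an estimated 1.7-fold higher number from compound 3 to compound 4 (0.22 log units; within the scatter), and the wide range also allows for no change beyond the scatter. For compound 4 the estimated value is 10000 nM, with an expected range from 3000 nM to 30000 nM.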

Compound 4, half-maximal inhibitory concentration: > 10000 nM
Compound 4: only a limit was reported (the forecaster's own chance of this, stated with the estimate: 25%); the middle value sits exactly at the limit.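

Compound 4 reaches only a limit, not a number, in this assay: the limit of > 10000 nM in this assay, at which 1 of the 4 values shown sits. The two new steps are therefore floors rather than measured sizes, reading an at least 1.6-fold higher number from compound 3 to compound 4 (0.22 log units; that floor lies within the scatter) and an at least 1.6-fold higher number from compound 2 to compound 4 (0.22 log units; that floor lies within the scatter), and the true gap could be that small or much larger. Within the data shown here, compounds 2 and 3 differed only in the length of a chain that kept its amino group, whereas compound 4 is the first with a readable result to carry something else on this saturated chain carbon, and it gives no sign of a stronger number than either of them, though its limit cannot show whether it is truly weaker.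

The compounds shown leave open whether the loss of aminomethyl or the arrival of methoxycarbonyl drives this result, as the two happen in a single step, and compound 1 offers no help with its entry of "not determined" (no result reported). A carboxylic acid or a simple primary amide on the same chain carbon, or a 2-hydroxyethyl group in place of 2-aminoethyl, would help to pull these two parts of the change apart.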